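Cytotoxicity in human astrocytes: swapping the urea aryl group

The source may report more compounds than this note shows. Statements on the series, on what has been measured and on what is new or still open speak of the compounds shown alone.

Compound 1, `O=C(Nc1ccccc1F)Nc1cc2ncncc2cc1OCc1cccc(F)c1`, in an ADME assay on cells (Astrocyte, Homo sapiens) for cytotoxicity, read by WST assay, with a stated time of 72 h (a higher number here means a weaker inhibitor, a lower number a stronger inhibitor), gives > 10000 nM; this is a limit of the assay, not a number.
Compound 2, `O=C(Nc1ccccc1F)Nc1cc2ncncc2cc1OCc1ccccc1F`, in this assay gives 10000 nM.
Compound 3, `O=C(Nc1cccc(Cl)c1)Nc1cc2ncncc2cc1OCc1ccccc1`, in this assay gives 7400 nM.

Compound 1 therefore stands at the upper limit of this assay, with no measured number of its own; the reading rests on (the limit of > 10000 nM in this assay, at which 1 of the 3 values shown sits). Among the measured compounds shown here, the one measured step, a number no higher from compound 1 to compound 2 (the limit leaves the size open), touches only the benzylic ring and says nothing about the urea aryl group. Compound 3 differs from compound 1 in two places at once, so its value can be set beside those of compounds 1 and 2 but not read as a step.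

Compound 4, `O=C(Nc1ccc(C(F)(F)F)cc1)Nc1cc2ncncc2cc1OCc1cccc(F)c1`, carries the change (4-(trifluoromethyl)phenyl in place of 2-fluorophenyl on an amide-type nitrogen). For the measured compounds named here, no measured step bears on this change, and the three values shown all sit near the limit. Compound 4 is therefore expected to stay in the same weak region, with a number no higher from compound 1 to compound 4 (the limit leaves the size open) as the expected step. The estimate for compound 4 in this assay is 10000 nM, within 5000 nM to 30000 nM.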

Compound 4, half-maximal inhibitory concentration: 8900 nM
Beside the measured number, compound 4's estimate is 1.1-fold (0.05 log units) above it; the range from low to high includes it.
By their numbers in this assay, from the lowest: compounds 3, 4 and 2 (each within the scatter of the next).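

Among the compounds shown here, compound 4 gives the first reading at the urea aryl position with the rest of compound 1 held constant: in this assay, the exchange of 2-fluorophenyl for 4-(trifluoromethyl)phenyl on the amide-type nitrogen gives an at least 1.1-fold lower number from compound 1 to compound 4 (0.05 log units; that floor lies within the scatter) and nothing more can be claimed for it. As far as these compounds go, the true size of this step stays open, because the reading for compound 1 is a limit of the assay: the limit of > 10000 nM in this assay, at which 1 of the 4 values shown sits. The group grows from 7 to 10 heavy atoms at this place, yet the step cannot be told from the scatter.

From the compounds shown here alone, whether an amine or a carboxylic acid on this aryl ring, or a longer chain in its place, would give a clear step remains open. So does whether the same exchange would read alike on the core of compound 2.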